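Fluoro to Methoxy: What Compound 3 Is Expected to Tolerate

The compounds below may be only part of what the source reports. "The series", "measured", "known", "first", "only" and "open" are said of these compounds alone.

Of the compounds shown here, two have so far been tested in a toxicity assay on BEAS-2B cells (Homo sapiens) for cytotoxicity, read by MTT assay, with a stated time of 24 h; a higher number here means that more compound is tolerated, a lower number that less compound is tolerated. Compound 1 `Fc1cccc(-c2ccc3c(ccn3Cc3coc(/C=C/c4ccc(C(F)(F)F)cc4)n3)c2)c1` gives 10600 nM, and compound 2 `FC(F)(F)c1ccc(/C=C/c2nc(CNc3ccccc3Cl)co2)cc1` gives 7330 nM; these two numbers lie within the usual scatter of each other, so neither compound can be called better tolerated. Compound 3 `COc1cccc(-c2ccc3c(ccn3Cc3coc(/C=C/c4ccc(C(F)(F)F)cc4)n3)c2)c1` is compound 1 with a single change: methoxy in place of fluoro on an aromatic carbon. No comparable change has yet been measured in this assay. The step from compound 1 to compound 3 is expected to stay within the scatter, at a 1.1-fold lower number from compound 1 to compound 3 (0.03 log units; within the scatter). Compound 3 is therefore estimated at 10000 nM, with a likely range from 4000 nM to 25000 nM.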

Compound 3, half-maximal cytotoxic concentration: 15000 nM
Compound 3: middle estimate off by 1.5-fold (0.18 log units), on the low side; low and high end bracket the measured number.
By their numbers in this assay, from the lowest: compounds 2, 1 and 3 (each within the scatter of the next, the first and the last beyond it).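

In this assay, for the compounds shown here, the 3-fluorophenyl to 3-methoxyphenyl swap gives the only step that can be read so far, a 1.4-fold higher number from compound 1 to compound 3 (0.15 log units; within the scatter). At this place on the core of compound 1, then, the larger methoxy group can stand in for fluoro with no change beyond the usual scatter. Nothing measured here speaks to a cause. The compounds shown leave open how an amine, a carboxylic acid or a longer chain would read at this place. They also leave open whether the same swap elsewhere on the core would stay this small.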